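A few compounds are considered here, and "the series" means these few. Any claim that something is new, unique, unknown or untested is made for them only; others in the source may bear on it.

In a functional assay on A549 cells (Homo sapiens) for cytotoxicity, read by MTT assay, with a stated time of 48 h (a higher number here means a weaker inhibitor, a lower number a stronger inhibitor), compound 1 (`COc1c(OCc2nc3ccccc3[nH]2)cc(O)c2c(=O)cc(-c3ccccc3)oc12`) gives > 100000 nM as its reading, and this is a limit of the assay, not a number. Within the data shown here, compound 2 (`CC(C)NCCOc1c(O)cc(O)c2c(=O)cc(-c3ccccc3)oc12`) has "not determined" (no result reported) as its entry, and compound 3 (`O=c1cc(-c2ccccc2)oc2c(OCCNCCO)c(O)cc(O)c12`) has "not determined" (no result reported) as its entry, so no measured step is available as a guide. Compound 4 (`COc1c(OCCCCN2CCCCC2)cc(O)c2c(=O)cc(-c3ccccc3)oc12`) keeps the core of compound 1 and carries one change: 3-(piperidin-1-yl)propyl in place of 1H-benzimidazol-2-yl on a saturated chain carbon bound to an oxygen on an aromatic ring (in other words, a 4-(piperidin-1-yl)butyl group takes the place of the (1H-benzimidazol-2-yl)methyl group). In this assay a moderate step towards stronger inhibition is expected, estimated as an at least 3.3-fold lower number from compound 1 to compound 4 (0.52 log units; beyond the scatter) and resting only on this structural change. For compound 4 an estimate of 30000 nM is expected, with 8000 nM to 100000 nM as the range of likely readings.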

Compound 4, half-maximal inhibitory concentration: 1150 nM
Compound 4: the middle estimate sits 26-fold (1.42 log units) above what was measured; measured number outside the range, below it.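

In this assay this change on a saturated chain carbon bound to an oxygen on an aromatic ring gives an at least 86-fold lower number from compound 1 to compound 4 (1.93 log units; beyond the scatter) and shows that the group here can strongly move the reading. Among these compounds, compound 4 also gives the first single number on the shared core. The reading of compound 1 is a limit, not a number, so the step has no upper end: the limit of > 100000 nM in this assay, at which 1 of the 4 values shown sits. The compounds shown do not separate the roles of the piperidine ring and the chain. A morpholine ring or a shorter chain at this place would begin to separate them.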